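A few compounds are considered here, and "the series" means these few. Any claim that something is new, unique, unknown or untested is made for them only; others in the source may bear on it.

Measured so far:

Compound 1, `O=C1/C(=C2/C(=O)N([C@@H]3O[C@H](CO)[C@@H](O)[C@H](O)[C@H]3O)c3ccccc32)Nc2ccccc21`: 14400 nM
Compound 2, `O=C1/C(=C2/C(=O)N([C@@H]3O[C@H](CO)[C@@H](O)[C@H](O)[C@@H]3O)c3ccccc32)Nc2ccccc21`: 10600 nM
Compound 3, `Cc1cc(C)c2c(c1)N([C@H]1O[C@@H](C)[C@H](O)[C@@H](O)[C@H]1O)C(=O)/C2=C1\Nc2ccccc2C1=O`: > 12500 nM (a limit, not a number)

All three were tested in a functional assay on 5637 cells (Homo sapiens) for antiproliferative activity, read by crystal violet staining, with a stated time of 96 h; on this read-out higher numbers stand for weaker inhibition and lower numbers for stronger inhibition. Compound 3 reached only a limit of the assay, (the limit of > 12500 nM in this assay, at which 1 of the 3 values shown sits). For the measured compounds named here, compound 2 stands beside compound 1, the only other compound with a full number: the step of a 1.4-fold lower number from compound 1 to compound 2 (0.13 log units; within the scatter) is within the scatter, so the two cannot be told apart. Going by the values given here, that step is the one measured comparison that bears on the next compound, since (the fact that compounds 1 and 2 differ only in the configuration as drawn).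

Compound 4, `O=C1/C(=C2/C(=O)N([C@@H]3O[C@H](CO)[C@H](O)[C@H](O)[C@H]3O)c3ccccc32)Nc2ccccc21`, has not been measured. It differs from compound 2 as follows: the two compounds have the same atoms and bonds and differ only in configuration as drawn: 2 of 6 stereo elements differ; a stereocentre at a saturated ring carbon is drawn S in compound 2 and R in compound 4; a stereocentre at a saturated ring carbon is drawn S in compound 2 and R in compound 4. Among the compounds with values here, the change is thus of the same kind as the one between compound 1 and compound 2, only at two centres rather than one. That earlier change left the value within the scatter, so no step beyond the scatter is expected here either, in either direction: a 1.1-fold higher number from compound 2 to compound 4 (0.05 log units; within the scatter). Compound 4 is therefore estimated at 12000 nM, between 6000 nM and 25000 nM.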

Compound 4, half-maximal inhibitory concentration: 24900 nM
Compound 4: the middle estimate sits 2.1-fold (0.32 log units) below what was measured, and the stated range covers the measured number.
By their numbers in this assay, from the lowest: compounds 2, 1 and 4 (each within the scatter of the next, the first and the last beyond it).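

In this assay, there is now a 2.3-fold higher number from compound 2 to compound 4 (0.37 log units; beyond the scatter), the first step among these compounds to pass the scatter, and it comes with no change in atoms or bonds: the fact that compounds 2 and 4 differ only in the configuration as drawn. Taken alone, the single centre that separates the next pair moves the number by no more than the scatter, with a 1.7-fold higher number from compound 1 to compound 4 (0.24 log units; within the scatter), so this change on its own cannot be read. The configuration of these saturated ring carbons therefore shows up only modestly, and only when compound 2 and compound 4 are set against each other across two centres.

As far as these compounds go, what remains open is whether the other stereocentres of the ring behave in the same way. It is also unknown whether an amine or a carboxylic acid in place of a hydroxyl group on that ring would leave the number unchanged or shift it further.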